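The compounds below may be only part of what the source reports. "The series", "measured", "known", "first", "only" and "open" are said of these compounds alone.

Among the compounds with values here, in an ADME assay on HEK293 cells (Homo sapiens) for cytotoxicity, read by MTT assay, with a stated time of 72 h (a higher number here means a weaker inhibitor, a lower number a stronger inhibitor), compound 1 `Cc1cc(/C=C/c2ccc(O)cc2)[nH]n1` gives 77400 nM and is the higher of the two numbers so far, with compound 2 `COc1ccc(/C=C/c2cc(C)n[nH]2)cc1` at 12900 nM as its only neighbour. Compound 3 `Cc1cc(/C=C/c2ccc(O)c(O)c2)[nH]n1` carries hydroxy in place of hydrogen on an aromatic carbon on the core of compound 1: hydroxy in place of hydrogen on an aromatic carbon, ortho to a hydroxy group. Within the data shown here, the only measured step, a 6.0-fold lower number from compound 1 to compound 2 (0.78 log units; beyond the scatter) for methyl in place of hydrogen on an oxygen, is a different change and bears only indirectly. A modest move towards a lower number is expected, with the estimated 2.6-fold lower number from compound 1 to compound 3 (0.41 log units; beyond the scatter) smaller than that measured step. For compound 3 the estimate is 30000 nM with 10000 nM to 90000 nM as its expected range.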

Compound 3, half-maximal inhibitory concentration: 29700 nM
For compound 3 the middle estimate is 1.0-fold (0.00 log units) above the measured one, within the range that was stated.
By their numbers in this assay, from the lowest: compound 2; then compound 3; then compound 1.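

In this assay, adding hydroxy in place of hydrogen on an aromatic carbon, ortho to a hydroxy group, gives a 2.6-fold lower number from compound 1 to compound 3 (0.42 log units; beyond the scatter). This shows that the number responds to a change on a ring carbon, whereas the earlier step changed only the hydroxy oxygen. Nothing available explains this shift. As far as these compounds go, it remains open whether an amine or a carboxylic acid at this position would also lower the number. A longer chain in place of the methyl on the oxygen of compound 2 is also untested here.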